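Fluorophenylamino replacement for the piperidine amide in cathepsin S series

A few compounds are considered here, and "the series" means these few. Any claim that something is new, unique, unknown or untested is made for them only; others in the source may bear on it.

Measured so far in an assay on isolated protein for inhibition of cathepsin S (Homo sapiens), read by fluorescence, with a stated time of 20 min; on this read-out higher numbers stand for weaker inhibition and lower numbers for stronger inhibition:
- compound 1, `N#CC1(NC(=O)[C@@H]2C[C@@H](S(=O)(=O)c3ccccc3)C[C@H]2C(=O)N2CC3(COC3)C2)CC1`, gives 3 nM
- compound 2, `N#CC1(NC(=O)[C@@H]2C[C@@H](S(=O)(=O)c3ccccc3)C[C@H]2C(=O)N2CCCCC2)CC1`, gives 0.8 nM
- compound 3, `CC1CCN(C(=O)[C@@H]2C[C@H](S(=O)(=O)c3ccccc3)C[C@H]2C(=O)NC2(C#N)CC2)CC1`, gives 0.5 nM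

Compound 3 holds the lowest number of the three, but its separation from compound 2 is a 1.6-fold lower number from compound 2 to compound 3 (0.20 log units; within the scatter), which is within the scatter; only against compound 1 is the gap clear, at a 6.0-fold lower number from compound 1 to compound 3 (0.78 log units; beyond the scatter).

Compound 4 is `N#CC1(NC(=O)[C@@H]2C[C@@H](S(=O)(=O)c3ccccc3)C[C@H]2C(=O)Nc2ccc(F)cc2)CC1`. Relative to compound 3 the change is (4-fluorophenyl)amino in place of 4-methylpiperidin-1-yl on a carbonyl carbon. The measured steps on this carbonyl carbon are a 3.8-fold lower number from compound 1 to compound 2 (0.57 log units; beyond the scatter) and a 6.0-fold lower number from compound 1 to compound 3 (0.78 log units; beyond the scatter), both exchanges of one saturated ring for another; none of them involves an aromatic ring or introduces a hydrogen-bond donor at this position, so they set only a rough scale. Changes here have moved the number by modest amounts, and the present change is larger in kind than any measured one. A modest rise in the number is expected for compound 4, with the step from compound 3 estimated as a 5.0-fold higher number from compound 3 to compound 4 (0.70 log units; beyond the scatter). Compound 4 is therefore estimated at 2.5 nM, within 0.6 nM to 12 nM.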

Compound 4, half-maximal inhibitory concentration: 26 nM
The estimate for compound 4 lay 10-fold (1.02 log units) below the measured number; the whole stated range lies below it.
By their numbers in this assay, from the lowest: compounds 3 and 2 (each within the scatter of the next); then compound 1; then compound 4.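

In this assay the position on the carbonyl carbon turns out to be far less forgiving than the exchanges among saturated rings had indicated: (4-fluorophenyl)amino gives a 52-fold higher number from compound 3 to compound 4 (1.72 log units; beyond the scatter) and a 33-fold higher number from compound 2 to compound 4 (1.51 log units; beyond the scatter), both large. Compound 4 also stands apart from the compound with the two four-membered rings, with an 8.7-fold higher number from compound 1 to compound 4 (0.94 log units; beyond the scatter), so it has the highest number of the four. Within the data shown here, it is the only compound here with an aromatic ring or a hydrogen-bond donor on this carbonyl carbon, and no measurement at hand accounts for the rise.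

The compounds shown do not separate the aromatic ring, the amide hydrogen and the fluorine as sources of the step. Cyclohexylamino, phenylamino and (4-fluorophenyl)(methyl)amino at this carbonyl carbon would each isolate one of these features.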